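Adding a Second Fluoro to a Quinoline Urea: Solubility Outlook

The source may report more compounds than this note shows. Statements on the series, on what has been measured and on what is new or still open speak of the compounds shown alone.

Measured compounds in a physicochemical assay for solubility, at pH 7.4; a lower number here means a less soluble compound, a higher number a more soluble compound:
compound 1 `Cc1cc(NC(=O)Nc2ccccc2C(F)(F)F)c2ccccc2n1` gives 3800 nM
compound 2 `Cc1cc(NC(=O)Nc2ccccc2F)c2ccccc2n1` gives 3800 nM
compound 3 `CSc1ccccc1NC(=O)Nc1cc(C)nc2ccccc12` gives 21000 nM

In this assay compound 2 stands level with compound 1 at the digits shown; together they are the lowest of the three numbers, and compound 3 stands apart from them (a 5.5-fold higher number from compound 2 to compound 3 (0.74 log units; beyond the scatter)). Compound 4 `Cc1cc(NC(=O)Nc2ccc(F)cc2F)c2ccccc2n1` differs from compound 2 by a single change on the fluoro-bearing ring: fluoro in place of hydrogen on an aromatic carbon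

Among the compounds with values here, no measured step adds a fluoro in place of hydrogen, so the expectation rests on neighbouring steps. The swap of trifluoromethyl for fluoro gave no change at the digits printed from compound 1 to compound 2 (within the scatter), showing that the size of a small halogen-containing group at that ring changed the number little, while only the methylsulfanyl compound moved the reading (a 5.5-fold higher number from compound 2 to compound 3 (0.74 log units; beyond the scatter)). A second fluoro is therefore expected to leave this assay close to where compound 2 sits, with a step of a 1.3-fold lower number from compound 2 to compound 4 (0.10 log units; within the scatter), if anything a slightly lower number.

Compound 4 is estimated at 3000 nM, within a range of 1200 nM to 8000 nM.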

Compound 4, solubility: 3000 nM
Estimate against measurement, compound 4: no gap at the digits printed, and the stated range covers the measured number.
By their numbers in this assay, from the lowest: compounds 4, 1 and 2 (each within the scatter of the next); then compound 3.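

Within the data shown here, compound 4 gives the first direct reading of a fluoro in place of hydrogen on this ring, at a carbon meta to a fluoro group and para to a large group, and in this assay the step reads a 1.3-fold lower number from compound 2 to compound 4 (0.10 log units; within the scatter) for this change. The earlier steps shown here only exchanged one group for another at a single place, whereas this one shows that a second group can be added at a new place on the ring without the number leaving the scatter. No measurement available here explains this outcome.

From the compounds shown here alone, it remains open whether an amine, a carboxylic acid or a longer chain at this carbon would also stay within the scatter. Among these compounds, also open is whether methylsulfanyl, the only group here with steps beyond the scatter, would keep its higher number alongside a second fluoro.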